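A ring change on compound 2

The compounds below may be only part of what the source reports. "The series", "measured", "known", "first", "only" and "open" are said of these compounds alone.

In a functional assay on MCF7 cells (Homo sapiens) for inhibition (a lower number here means a stronger inhibitor, a higher number a weaker inhibitor), three compounds sharing one core have been measured. Compound 1 `O=C(C1CC1)N(O)c1ccc(Cl)cc1` reports only a limit, > 100000 nM. Compound 3 `O=C(C1CCCCC1)N(O)c1ccc(Cl)cc1` gives 80000 nM. Compound 2 `O=C(CCC1CCCC1)N(O)c1ccc(Cl)cc1` gives 10000 nM, the lowest of the two actual numbers, with compound 3 beyond the scatter above it.

Compound 4 `O=C(CC1CCCCC1)N(O)c1ccc(Cl)cc1` differs from compound 2 by one change, cyclohexyl in place of cyclopentylmethyl on a saturated chain carbon bound to a carbonyl carbon. For the measured compounds named here, no measured pair shows this change directly. A moderate rise in this assay is expected, pointing to weaker inhibition, and this rests on compound 3 at 80000 nM, which also carries cyclohexyl. The expected step is a 2.2-fold higher number from compound 2 to compound 4 (0.34 log units; beyond the scatter). Compound 4 is estimated at 22000 nM, within an expected range of 7000 nM to 70000 nM.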

Compound 4, half-maximal inhibitory concentration: 10000 nM
Estimate against measurement, compound 4: 2.2-fold (0.34 log units) above, within the range that was stated.
By their numbers in this assay, from the lowest: compounds 2 and 4 (each within the scatter of the next); then compound 3. At a limit, above all of these: compound 1.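

In this assay, cyclohexyl in place of cyclopentylmethyl on a saturated chain carbon bound to a carbonyl carbon gives no change at the digits printed from compound 2 to compound 4 (within the scatter). For the compounds shown here, this is the first direct reading at this position, and it shows that these two groups, with the same heavy-atom count, cannot be told apart here. Nothing at hand explains this result.

Going by these compounds, whether an open hexyl chain or a phenyl ring at this position would give a similar number remains open. So does the effect of an amine on the cyclohexyl ring.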